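From Fluorophenyl to Dichlorophenyl on a Shared Core

The compounds below may be only part of what the source reports. "The series", "measured", "known", "first", "only" and "open" are said of these compounds alone.

Of the compounds shown here, three of one shared core have been tested in a functional assay (muscle tissue) with Cavia porcellus as the target; on this read-out lower numbers stand for an effect already at smaller amounts and higher numbers for an effect only at larger amounts of compound. Compound 1 `COC(=O)C1=C(C)NC(C)=C(C(=O)OC)C1c1ccccc1` gives 28.2 nM, and compound 3 `COC(=O)C1=C(C)N=C(C)/C(=C(\O)OC)C1c1cc([N+](=O)[O-])ccc1Cl` gives 30.2 nM. Compound 2 `COC(=O)C1=C(C)N=C(C)/C(=C(\O)OC)C1c1ccc(F)cc1` gives 129 nM, the highest of the three numbers, so its effect appears only at the largest amount; its gaps to compound 3 and to compound 1 both lie beyond the scatter. Compound 4 `COC(=O)C1=C(C)N=C(C)/C(=C(\O)OC)C1c1cccc(Cl)c1Cl` differs from compound 2 in one place: 2,3-dichlorophenyl in place of 4-fluorophenyl on a saturated ring carbon. For the measured compounds named here, no measured pair shows this change directly. Since the other two compounds sit well below compound 2, and compound 3 gives 30.2 nM, a downward step beyond the scatter is expected, roughly a 5.2-fold lower number from compound 2 to compound 4 (0.71 log units; beyond the scatter). Compound 4 is therefore estimated at 25 nM, most likely between 6 nM and 100 nM.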

Compound 4, half-maximal effective concentration: 19.1 nM
Beside the measured number, compound 4's estimate is 1.3-fold (0.12 log units) above it; low and high end bracket the measured number.
By their numbers in this assay, from the lowest: compounds 4, 1 and 3 (each within the scatter of the next); then compound 2.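

For the compounds shown here, the first direct reading at this position comes from 2,3-dichlorophenyl in place of 4-fluorophenyl, which gives a 6.8-fold lower number from compound 2 to compound 4 (0.83 log units; beyond the scatter) in this assay. With the rest of the shared core unchanged, the group on this saturated ring carbon alone can move the number beyond the scatter. Nothing available explains this step.
On these data alone, because the swap removes fluorine and adds two chlorines at once, the share of each remains open. Also open, as far as these compounds go, is how a phenyl carrying a single chlorine, an amine or a carboxylic acid would behave here.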